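Nitroimidazooxazine series: cytotoxicity limits and a trifluoromethyl swap

The source may hold more compounds than are shown below. What is called first, only, known or untested is meant among the compounds shown, and "the series" means these compounds.

Compound 1 `O=[N+]([O-])c1cn2c(n1)OCC(COc1ccc(-c3ccc(OC(F)(F)F)cc3)cn1)C2` and compound 2 `O=[N+]([O-])c1cn2c(n1)OCC(COc1ccc(-c3ccc(C(F)(F)F)cc3)cn1)C2` share a core and differ by trifluoromethyl in place of trifluoromethoxy on an aromatic carbon. In an ADME assay on Vero cells (Chlorocebus sabaeus) for cytotoxicity, with a stated time of 72 h (on this read-out higher numbers stand for weaker inhibition and lower numbers for stronger inhibition), compound 1 gives only the limit > 128000 nM. Compound 2 likewise gives only the limit > 128000 nM. The step that the two limits leave unreadable from compound 1 to compound 2 therefore cannot be sized. Compound 3 `O=[N+]([O-])c1cn2c(n1)OCC(COCc1ccc(-c3ccc(OC(F)(F)F)cc3)cc1)C2` carries a different core; the difference between the two cores is not broken down here. In this assay compound 3 also gives only the limit > 128000 nM. Compound 4 `O=[N+]([O-])c1cn2c(n1)OCC(COCc1ccc(-c3ccc(C(F)(F)F)cc3)cc1)C2` differs from compound 3 by trifluoromethyl in place of trifluoromethoxy on an aromatic carbon, the same change as between compound 1 and compound 2. Given (the limit of > 128000 nM in this assay, at which 3 of the 3 values shown sit), the step that the limit leaves unreadable from compound 3 to compound 4 is expected to remain unreadable in the same way. Compound 4 is accordingly expected to give around 200000 nM, likely between 100000 nM and 400000 nM, most probably reported as a limit once more.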

Compound 4, half-maximal inhibitory concentration: 38000 nM
Beside the measured number, compound 4's estimate is 5.3-fold (0.72 log units) above it, and the stated range ends above it.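

On the core of compound 3, trifluoromethyl in place of trifluoromethoxy on an aromatic carbon gives, in this assay, an at least 3.3-fold lower number from compound 3 to compound 4 (0.52 log units; beyond the scatter). On the core of compound 1 the same change cannot be read, so the step is not shown either to carry over to that core or to fail to carry over: the limit of > 128000 nM in this assay, at which 3 of the 4 values shown sit. With a single readable pair on a single core, the direction of the step holds only for compound 3 and compound 4, and no rule for the series follows.

Still open, as far as these compounds go, is how a carboxylic acid, an amine or a nitrile on that aromatic carbon would compare with trifluoromethyl and trifluoromethoxy on either core. Also open, from the compounds shown here alone, is how much of the difference between compound 2 and compound 4 comes from the core alone.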